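The source may report more compounds than this note shows. Statements on the series, on what has been measured and on what is new or still open speak of the compounds shown alone.

Measured so far in a physicochemical assay for solubility, read by mass spectrometry, in phosphate buffer, with a stated time of 24 h, at pH 3; a lower number here means a less soluble compound, a higher number a more soluble compound:
compound 1 `O=C(Nc1ccc(C(F)(F)F)cc1)NC1CCN(C(=O)C2=COCC2)CC1` gives 8.2 ug/mL.
compound 2 `O=C(Nc1ccc(OC(F)(F)F)cc1)NC1CCN(C(=O)C2=COCC2)CC1` gives 73 ug/mL.
compound 3 `O=C(Nc1ccc(OC(F)(F)F)c(F)c1)NC1CCN(C(=O)N2CCOCC2)CC1` gives 294 ug/mL.

Compound 1 stands lowest of the three numbers. Its nearest neighbour is compound 2, reached by an 8.9-fold higher number from compound 1 to compound 2 (0.95 log units; beyond the scatter) with trifluoromethoxy in place of trifluoromethyl on an aromatic carbon. Compound 3 differs from compound 1 in more than one place, so its higher value cannot be tied to any single change.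

The step to compound 4 `O=C(Nc1ccc(C(F)(F)F)cc1)NC1CCN(C(=O)[C@@H]2CCOC2)CC1` alters the other end of the shared core: a group of 5 heavy atoms (4 carbon, 1 oxygen; one five-membered non-aromatic ring with 1 hetero atom) in place of a group of 5 heavy atoms (4 carbon, 1 oxygen; one five-membered non-aromatic ring with 1 hetero atom), on a carbonyl carbon. The group that leaves carries a double bond outside aromatic rings; the group that enters has none and carries a defined stereocentre, while the counts of heavy atoms, donors and acceptors are unchanged.

Among the measured compounds shown here, no measured step bears on this change. For the measured compounds named here, the only step available, an 8.9-fold higher number from compound 1 to compound 2 (0.95 log units; beyond the scatter), concerns the substituent on the aromatic carbon and leaves the carbonyl-bearing ring untouched. Going by the values given here, with no direct precedent and like-for-like counts on both sides, the expected step from compound 1 to compound 4 in this assay is a 1.5-fold higher number from compound 1 to compound 4 (0.17 log units; within the scatter), not beyond the scatter, with a wide range to reflect the lack of evidence.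

Compound 4 is therefore expected to give about 12 ug/mL in this assay, between 4 ug/mL and 40 ug/mL.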

Compound 4, solubility: 58 ug/mL
Compound 4: middle estimate off by 4.8-fold (0.68 log units), on the low side; measured number above the stated range.
By their numbers in this assay, from the lowest: compound 1; then compounds 4 and 2 (each within the scatter of the next); then compound 3.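

In this assay, the position on a carbonyl carbon whose other neighbours are amide-type nitrogen in a ring proves responsive: oxolan-3-yl in place of the ring carrying a double bond gives a 7.1-fold higher number from compound 1 to compound 4 (0.85 log units; beyond the scatter). The earlier compounds shown here offered a single-place step only on the aromatic carbon, an 8.9-fold higher number from compound 1 to compound 2 (0.95 log units; beyond the scatter), so compound 1 now has a step beyond the scatter at each end of the shared core, and this new one comes with the counts of heavy atoms, donors and acceptors unchanged. What changes is the loss of a double bond outside aromatic rings and the gain of a defined stereocentre, and nothing available explains why this exchange moves the number.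

The two features of the change remain tied together in compound 4, and the mirror-image form of oxolan-3-yl would be needed to separate the stereocentre from the loss of the double bond. Also open, as far as these compounds go, is whether a similar step would appear with trifluoromethoxy on the aromatic carbon, or with an open-chain methoxyethyl group or an amine on the carbonyl carbon.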